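A few compounds are considered here, and "the series" means these few. Any claim that something is new, unique, unknown or untested is made for them only; others in the source may bear on it.

Compound 1 `N#Cc1ccc(C2OCC(C/C=C\CCC(=O)O)C(c3cccnc3)O2)cc1`: 24 nM
Compound 2 `O=C(O)CC/C=C\CC1COC(c2cccnc2)OC1c1cccnc1`: 220 nM
Compound 3 `Cc1ccc(C#N)c(OC(C)(C)C2OCC(C/C=C\CCC(=O)O)C(c3cccnc3)O2)c1`: 50 nM

In an assay for inhibition of Thromboxane-A synthase (Homo sapiens), using microsomes (a lower number here means a stronger inhibitor, a higher number a weaker inhibitor), compound 3 stands second of the three numbers, between compound 1 with 24 nM and compound 2 with 220 nM, beyond the scatter from each.

Compound 4 `CC(C)(Oc1ccc(F)cc1)C1OCC(C/C=C\CCC(=O)O)C(c2cccnc2)O1` differs from compound 3 by 4-fluorophenyl in place of 2-cyano-5-methylphenyl on an oxygen on a saturated carbon. For the measured compounds named here, the only measured step, a 9.2-fold higher number from compound 1 to compound 2 (0.96 log units; beyond the scatter), concerns a group on a saturated ring carbon, not the aryl group on the ether oxygen, so it bears only loosely on this change; no step at the ether position has been measured. Compound 3 and compound 1 both carry a nitrile-bearing aryl ring, which compound 4 lacks. A modest weakening is therefore expected, a 1.8-fold higher number from compound 3 to compound 4 (0.26 log units; within the scatter), with wide uncertainty. Compound 4 is estimated at 90 nM, within 30 nM to 300 nM.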

Compound 4, half-maximal inhibitory concentration: 51 nM
Compound 4: the middle estimate sits 1.8-fold (0.25 log units) above what was measured; low and high end bracket the measured number.
By their numbers in this assay, from the lowest: compound 1; then compounds 3 and 4 (each within the scatter of the next); then compound 2.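

In this assay the exchange of 2-cyano-5-methylphenyl for 4-fluorophenyl on an oxygen on a saturated carbon gives a 1.0-fold higher number from compound 3 to compound 4 (0.01 log units; within the scatter), so in this pair the aryl group on that oxygen tolerates the loss of both the nitrile and the methyl. A nitrile on this aryl ring is therefore not required to keep the number of compound 3. No measured property of these compounds bears on this result.

Still open, going by these compounds, is whether the aryl ring itself matters at this oxygen. An alkyl chain or a morpholine in its place would test that, and a methoxy group on the ring would widen the range of aryl substituents.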